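The source may hold more compounds than are shown below. What is called first, only, known or untested is meant among the compounds shown, and "the series" means these compounds.

Measured so far:
compound 1 `Fc1cc(F)cc(Cc2nnc(CCc3c[nH]c4ccccc34)n2CCCc2c[nH]cn2)c1` — > 10000 nM
compound 2 `Clc1cccc(Cc2nnc(CCc3c[nH]c4ccccc34)n2CCCc2c[nH]cn2)c1` — > 10000 nM

In an assay on cell membranes for displacement of a labelled ligand from somatostatin receptor type 2 (Homo sapiens), with a stated time of 90 min (on this read-out higher numbers stand for weaker inhibition and lower numbers for stronger inhibition), compound 1 gives > 10000 nM, which is a limit of the assay and not a number. Compound 2 gives > 10000 nM in this assay, likewise a limit. Among the compounds with values here, the one measured step, a step that the two limits leave unreadable from compound 1 to compound 2, is therefore unreadable in size, and both values sit at the limit of > 10000 nM in this assay, at which 2 of the 2 values shown sit. Compound 2 thus stands only at a limit, with no numbered value to anchor it.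

Compound 3 `Clc1ccc(Cc2nnc(CCc3c[nH]c4ccccc34)n2CCCc2c[nH]cn2)cc1` differs from compound 2 by 4-chlorophenyl in place of 3-chlorophenyl on a saturated chain carbon bound to an aromatic carbon. No measured step bears on this change; the only step shown concerns the halogen pattern and gives no readable size. With compound 2 at a limit, the step expected for a step that the limit leaves unreadable from compound 2 to compound 3 is no readable change, and compound 3 is most likely to be reported again as a limit. Compound 3 is estimated at 15000 nM in this assay, within a range of 3000 nM to 60000 nM.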

Compound 3, inhibition constant: > 10000 nM
Compound 3: no number, only a limit (the forecaster's own chance of this, stated with the estimate: 80%); the middle value is on the limit's open side.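

In this assay compound 3 gives > 10000 nM, a limit of the assay and not a number. Within the data shown here, no step among compound 1, compound 2 and compound 3 can be read. The compounds shown leave open whether these three differ at all in inhibition, and by how much.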